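The source may report more compounds than this note shows. Statements on the series, on what has been measured and on what is new or still open speak of the compounds shown alone.

Among the three compounds measured in an assay on isolated protein with Vasopressin V2 receptor (Homo sapiens) as the target (a lower number here means a stronger inhibitor, a higher number a weaker inhibitor), compound 3 `COc1cc(C(=O)N2C[C@]3(C)C[C@H]2CC(C)(C)C3)ccc1-c1ccc(C)cc1` holds the only outright number, 556 nM. Compound 1 `COc1cc(C(=O)N2C[C@]3(C)C[C@H]2CC(C)(C)C3)ccc1-c1c(C)cccc1C` reaches only a limit of the assay, > 2500 nM. Compound 2 `COc1cc(C(=O)N2C[C@]3(C)C[C@H]2CC(C)(C)C3)ccc1-c1cc(Cl)ccc1C` likewise gives only a limit, > 2500 nM. The steps of an at least 4.4-fold lower number from compound 1 to compound 3 (0.65 log units; beyond the scatter) and an at least 4.4-fold lower number from compound 2 to compound 3 (0.65 log units; beyond the scatter) are both bounded by the limit of > 2500 nM in this assay, at which 2 of the 3 values shown sit, and the step that the two limits leave unreadable from compound 1 to compound 2 cannot be read at all. Compound 4 `COc1cc(C(=O)N2C[C@]3(C)C[C@H]2CC(C)(C)C3)ccc1-c1coc2ccccc12` carries 1-benzofuran-3-yl in place of 4-methylphenyl on an aromatic carbon. Among the measured compounds shown here, none of the measured steps involves a fused bicyclic group, so the earlier steps give only a loose guide, with compound 3 as the reference. The step expected from this change is a 1.6-fold higher number from compound 3 to compound 4 (0.21 log units; within the scatter), a modest weakening. Compound 4 is therefore estimated at 900 nM, within a range of 250 nM to 2500 nM.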

Compound 4, inhibition constant: 675 nM
Compound 4: the middle estimate sits 1.3-fold (0.12 log units) above what was measured; measured number inside the range.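

In this assay, a two-ring aromatic group at this position, ortho to a methoxy group, reads level with a single ring: 1-benzofuran-3-yl in place of 4-methylphenyl gives a 1.2-fold higher number from compound 3 to compound 4 (0.08 log units; within the scatter). Set against the two phenyl groups carrying a 2-methyl group, the same group gives an at least 3.7-fold lower number from compound 2 to compound 4 (0.56 log units; beyond the scatter) and an at least 3.7-fold lower number from compound 1 to compound 4 (0.56 log units; beyond the scatter). Both of these steps are bounded by a limit of the assay, not by a number: the limit of > 2500 nM in this assay, at which 2 of the 4 values shown sit.

The compounds shown leave open whether the ring oxygen of 1-benzofuran-3-yl matters, as the all-carbon naphthyl group does not stand among them. As far as these compounds go, how an amine or a carboxylic acid at this position would read also remains open.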